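The compounds below may be only part of what the source reports. "The series", "measured", "known", "first", "only" and "open" are said of these compounds alone.

Compound 1 `COc1cc(-n2cnc3ccc(-c4ccc(C(C)=O)cc4)cc32)cc(OC)c1OC`: 450 nM
Compound 2 `COc1ccc(-c2ccc3ncn(-c4cc(OC)c(OC)c(OC)c4)c3c2)cc1O`: 44 nM

Both values come from a functional assay on SGC-7901 cells (Homo sapiens) for antiproliferative activity, read by MTT assay, with a stated time of 72 h; a higher number here means a weaker inhibitor, a lower number a stronger inhibitor. Compound 2 has the lower of the two numbers, so it is the stronger inhibitor of this pair. Going by the values given here, the only measured step is a 10-fold lower number from compound 1 to compound 2 (1.01 log units; beyond the scatter). In that step, 3-hydroxy-4-methoxyphenyl replaced 4-acetylphenyl, and the change lies well beyond the scatter.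

Compound 3 `COc1cc(-n2cnc3ccc(-c4cccc(Cl)c4)cc32)cc(OC)c1OC` has not been measured yet. The change from compound 2 is 3-chlorophenyl in place of 3-hydroxy-4-methoxyphenyl on an aromatic carbon. Among the compounds with values here, the group that leaves is the one that entered in the measured step, so that step is the best available guide, though 3-chlorophenyl itself has no measured example here. Within the data shown here, compound 1, at 450 nM, is the only measured compound lacking the 3-hydroxy-4-methoxyphenyl group. A rise of similar size to the measured step is therefore expected, in the opposite direction, and the expected step is a 9.1-fold higher number from compound 2 to compound 3 (0.96 log units; beyond the scatter). In this assay, compound 3 is estimated at 400 nM, within an expected range from 100 nM to 1500 nM.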

Compound 3, half-maximal inhibitory concentration: 1490 nM
Compound 3: middle estimate off by 3.7-fold (0.57 log units), on the low side, within the range that was stated.
By their numbers in this assay, from the lowest: compound 2; then compound 1; then compound 3.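

In this assay, the new step is a 34-fold higher number from compound 2 to compound 3 (1.53 log units; beyond the scatter). Going by these compounds alone, that step is larger than the one between compound 1 and compound 2, so what replaces 3-hydroxy-4-methoxyphenyl at this position matters, not only its removal. Groups without that hydroxy and methoxy pair also separate from each other: 3-chlorophenyl in place of 4-acetylphenyl gives a 3.3-fold higher number from compound 1 to compound 3 (0.52 log units; beyond the scatter) and so places compound 3 last of the three, although this is a modest step. With three different aromatic rings now tested on the same aromatic carbon of the shared core, the number moves beyond the scatter in every comparison, and 3-hydroxy-4-methoxyphenyl keeps the lowest value.

As far as these compounds go, it remains open whether the hydroxy or the methoxy of that ring accounts for the lower number of compound 2, and whether an amine or a carboxylic acid placed on the ring would bring a value closer to compound 2 or to compound 3. Nothing shown here gives a measured reason for any of these differences.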